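Swapping the outer aryl ring of compound 1 for a methylphenyl

This account rests on a few compounds, and the source may have more. Where it says the series, first, only, none or still open, it means among the compounds named here.

Compound 1 `CCOc1ccccc1-c1ccc(-c2nc3cnccc3c(N[C@H](CC)C(N)=O)c2C#N)cc1` is one of three measured compounds that share a core and differ only at the substituent on the ring nitrogen. In a physicochemical assay for lipophilicity, read by HPLC, at pH 7.5 (a lower number here means a more polar compound, a higher number a more lipophilic compound), compound 1 gives 3, level with compound 3 `CCOc1ccccc1-c1ccc(-c2nc3cnccc3c(N)c2C#N)cc1` at the digits shown, which in this assay gives 3; together they are the highest of the three numbers, while compound 2 `CCOc1ccccc1-c1ccc(-c2nc3cnccc3c(NC(COC)C(N)=O)c2C#N)cc1` gives 2.8. All three steps are small: a number 0.20 log units lower from compound 1 to compound 2 (within the scatter), no change at the digits printed from compound 1 to compound 3 (within the scatter), and a number 0.20 log units higher from compound 2 to compound 3 (within the scatter).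

Compound 4 `CC[C@@H](Nc1c(C#N)c(-c2ccc(-c3cccc(C)c3)cc2)nc2cnccc12)C(N)=O` departs from compound 1 at a different site. 3-methylphenyl in place of 2-ethoxyphenyl on an aromatic carbon The exchange sits on an aromatic carbon of a six-membered aromatic ring of carbon only, para to a large group.

For the measured compounds named here, none of the measured steps touch that ring; each concerns the group on the nitrogen, and each lies within the scatter. The measured set therefore gives no direct guide to this change, and the expectation rests on the structures alone. Compound 4 is expected to give 3 in this assay, with a range from 2.5 to 3.5. That estimate corresponds to a step of no change at the digits printed from compound 1 to compound 4 (within the scatter), which is expected to stay within the scatter.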

Compound 4, distribution coefficient: 3
Estimate against measurement, compound 4: no gap at the digits printed; the measured number falls inside the stated range.
By their numbers in this assay, from the lowest: compounds 2, 1, 3 and 4 (each within the scatter of the next).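

For the compounds shown here, the earlier compounds varied only the group on the nitrogen, whereas compound 4 is the first here to change the outer aryl ring, with 3-methylphenyl in place of 2-ethoxyphenyl on an aromatic carbon. In this assay the reading for this exchange is no change at the digits printed from compound 1 to compound 4 (within the scatter) and so, for this one pair, the site tolerates the swap without a shift beyond the scatter. That holds even though the leaving group has 9 heavy atoms and 1 hydrogen-bond acceptor, while the entering group has 7 heavy atoms and 0 hydrogen-bond acceptors, and no other kind of measurement is available to explain the outcome.

The exchange replaces the ethoxy group with a methyl group and also alters the substituent's place on the ring, so the compounds shown cannot separate these two changes or say whether each alone would leave the number level. Also open, as far as these compounds go, is whether an amine, a carboxylic acid or a longer alkyl chain on this outer ring would stay within the scatter of compound 1 in this assay or move the number clearly away from it.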